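Swapping the aryl substituent on a thiosemicarbazone series

The source may hold more compounds than are shown below. What is called first, only, known or untested is meant among the compounds shown, and "the series" means these compounds.

Among the measured compounds shown here, compound 2 `CC1=CC[C@@H]([C@@](C)(O)CCCC(C)(C)NC(=S)N/N=C\c2ccccc2[N+](=O)[O-])CC1` is one of two compounds measured in a functional assay on UACC-62 cells (Homo sapiens) for cytotoxicity, read by sulforhodamine B assay; a lower number here means a stronger inhibitor of growth, a higher number a weaker inhibitor of growth. In this assay compound 2 gives 6050 nM, the lowest of the two numbers, while compound 1 `COc1ccc(/C=N\NC(=S)NC(C)(C)CCC[C@](C)(O)[C@@H]2CC=C(C)CC2)cc1` gives 7420 nM. The step from compound 1 to compound 2 a 1.2-fold lower number from compound 1 to compound 2 (0.09 log units; within the scatter) replaced 4-methoxyphenyl with 2-nitrophenyl on the carbon double-bonded to nitrogen, and it left the number within the scatter.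

Compound 3 `CC1=CC[C@@H]([C@@](C)(O)CCCC(C)(C)NC(=S)N/N=C\c2ccccc2Cl)CC1` has not yet been measured in this assay. For the measured compounds named here, it differs from compound 2 by chloro in place of nitro on an aromatic carbon, so the only measured step that bears on it is the one from compound 1 to compound 2, which was also a change of the group on this aromatic ring and was within the scatter. On that basis no step beyond the scatter is expected for compound 3 in this assay, in either direction, so the estimated step of a 1.1-fold higher number from compound 2 to compound 3 (0.03 log units; within the scatter) is close to nothing. The number expected for compound 3 in this assay is 6500 nM, with a range from 3000 nM to 14000 nM.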

Compound 3, concentration for 50% growth inhibition: 53300 nM
Compound 3: middle estimate off by 8.2-fold (0.91 log units), on the low side, and the stated range ends below it.
By their numbers in this assay, from the lowest: compounds 2 and 1 (each within the scatter of the next); then compound 3.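

In this assay, the group on this aromatic ring turns out to matter: chloro in place of nitro, ortho to a large group, gives an 8.8-fold higher number from compound 2 to compound 3 (0.94 log units; beyond the scatter), a step beyond the scatter, unlike the earlier change on the same ring. Set against the 4-methoxyphenyl compound, the 2-chlorophenyl group gives a 7.2-fold higher number from compound 1 to compound 3 (0.86 log units; beyond the scatter), so compound 3 stands apart from both other compounds, while those two remain within the scatter of each other and the ring position is therefore not indifferent to every exchange. The change takes away a nitro group with its three heavy atoms and two hydrogen-bond acceptors and brings in a single chlorine, but nothing available here explains why growth inhibition is weaker in compound 3.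

Among the compounds shown here, with only three aryl groups on one shared core, these compounds cannot show whether the large step belongs to chloro alone or would also appear with other groups. From the compounds shown here alone, a fluoro group, an amine or a methoxy group on the same aromatic carbon remains open, as does whether the step from nitro to chloro would persist on a different core.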